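Removing the Methoxy Group from Compound 1

The source may report more compounds than this note shows. Statements on the series, on what has been measured and on what is new or still open speak of the compounds shown alone.

Compound 1 `COc1ccc(-c2nc(C)c(C(=O)CSc3nc(-c4ccc(OC)cc4)c(C#N)c(=O)[nH]3)s2)cc1` was tested in a functional assay on U-87MG ATCC cells for antiproliferative activity against U-87 MG (Homo sapiens), read by MTT assay, with a stated time of 48 h, tested at 10 uM (a lower number here means a stronger effect, a higher number a weaker effect of the compound at the concentration tested), where compound 1 gives 80.3%. Compound 3 `COc1ccc(-c2nc(SCC(=O)c3sc(-c4ccc(Cl)cc4)nc3C)[nH]c(=O)c2C#N)cc1` gives 88.3%, a number within the scatter of compound 1, while compound 2 `Cc1nc(-c2ccccc2)sc1C(=O)CSc1nc(N)c(C#N)c(-c2ccc(Cl)cc2)n1` gives 58.8%, a number beyond the scatter and lower than compound 1. For the measured compounds named here, the one step recorded between measured compounds, a number 8 percentage points higher from compound 1 to compound 3 (within the scatter), put chloro in place of methoxy on an aromatic carbon and stayed within the scatter. Compound 4 `COc1ccc(-c2nc(C)c(C(=O)CSc3nc(-c4ccccc4)c(C#N)c(=O)[nH]3)s2)cc1` differs from compound 1 by hydrogen in place of methoxy on an aromatic carbon. Going by the values given here, no measured step removes a methoxy group outright, and the only change seen at that ring did little, so the step is expected to be small: a number 1.7 percentage points higher from compound 1 to compound 4 (within the scatter). Compound 4 is therefore estimated to give 82%, with a range from 65% to 96%.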

Compound 4, a percentage reported as activity, at one concentration (the size of the read-out at that concentration, not a potency): 90.9%
The estimate for compound 4 lay 8.9 percentage points below the measured number, within the range that was stated.
By their numbers in this assay, from the lowest: compound 2; then compounds 1, 3 and 4 (each within the scatter of the next, the first and the last beyond it).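

Going from 4-methoxyphenyl to phenyl gave a number 10.6 percentage points higher from compound 1 to compound 4 (beyond the scatter), so in this assay this methoxy group, para to a large group, is the one of the two in compound 1 whose replacement moved the number beyond the scatter, towards a weaker effect. The earlier step, a number 8 percentage points higher from compound 1 to compound 3 (within the scatter), replaced the other methoxy group, not this one. Nothing shown bears on why the number rose. As far as these compounds go, whether a hydroxyl group, an amine or an ethoxy group at this position would give a lower number remains open.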